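Swapping the Imidazole Ring for an Oxadiazole: Stability Outlook

A few compounds are considered here, and "the series" means these few. Any claim that something is new, unique, unknown or untested is made for them only; others in the source may bear on it.

Compound 1, `C[C@H](c1ccccc1)N1C(=O)O[C@](Cc2ccccc2)(c2ncc(-c3ccccc3)[nH]2)C1=O`, is the most stable of the three compounds measured in an ADME assay (liver) for metabolic stability, with Liver microsome (Homo sapiens) as the target, using microsomes, with a stated time of 0.5 h, tested at 1 uM; a lower number here means that less of the compound is left, a higher number that more of the compound is left. In this assay compound 1 leaves 62% intact. Compound 2, `C[C@H](c1ccccc1)N1C(=O)O[C@](Cc2ccccc2)(c2ncc(Cc3ccccc3)[nH]2)C1=O`, has a benzyl in place of the phenyl on an aromatic carbon and gives 0%, while compound 3, `COc1cc(OC)cc(-c2cnc([C@@]3(Cc4ccccc4)OC(=O)N([C@H](C)c4ccccc4)C3=O)[nH]2)c1`, with a 3,5-dimethoxyphenyl at that aromatic carbon, gives 43%. The two changes move the number a number 62 percentage points lower from compound 1 to compound 2 (beyond the scatter) and a number 19 percentage points lower from compound 1 to compound 3 (beyond the scatter), both downward and both beyond the scatter, so compound 1 stands highest, with compound 3 nearest and compound 2 furthest away.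

Compound 4, `C[C@H](c1ccccc1)N1C(=O)O[C@](Cc2ccccc2)(c2nnc(-c3ccccc3)o2)C1=O`, differs from compound 1 in a different place: 5-phenyl-1,3,4-oxadiazol-2-yl in place of 5-phenyl-1H-imidazol-2-yl on a saturated ring carbon. The phenyl stays; what changes is the five-membered aromatic ring that sits on the saturated ring carbon of the shared core. Within the data shown here, none of the measured steps alters that ring, so they say little about this swap; they show only that the group on the aromatic carbon of that ring changes the amount left strongly. Among the measured compounds shown here, with no direct precedent, the expected step in this assay for compound 4 is small and uncertain, a number 7 percentage points lower from compound 1 to compound 4 (within the scatter). Compound 4 is therefore estimated at 55%, within a wide range from 25% to 85%.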

Compound 4, percent of the compound remaining: 82%
The estimate for compound 4 lay 27 percentage points below the measured number; measured number inside the range.
By their numbers in this assay, from the lowest: compound 2; then compound 3; then compound 1; then compound 4.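

Replacing 5-phenyl-1H-imidazol-2-yl with 5-phenyl-1,3,4-oxadiazol-2-yl on the saturated ring carbon gives, in this assay, a number 20 percentage points higher from compound 1 to compound 4 (beyond the scatter), so the five-membered aromatic ring itself matters here, not only the group on its aromatic carbon. This is also the first step from compound 1 that goes upward, since the two earlier changes at the aromatic carbon both lowered the number, and it puts compound 4 at the top of the four compounds. The swap changes the ring atoms and the hydrogen-bond counts together, from 1 donor and 1 acceptor to 0 donors and 3 acceptors, and no measurement shown separates these changes or explains the rise.

Benzyl and 3,5-dimethoxyphenyl appear only on the imidazole, so it remains open whether they would lower the number on the oxadiazole as they do on the imidazole. From the compounds shown here alone, it is equally open how much compound would be left with a methyl group or an amine in place of the phenyl on the oxadiazole ring.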